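A few compounds are considered here, and "the series" means these few. Any claim that something is new, unique, unknown or untested is made for them only; others in the source may bear on it.

The compounds measured so far:
compound 1, `O=C(OCC1CCCNC1)c1ccccc1-c1ccccc1`, which in an in vitro functional assay on HEK ts201 cells for antagonist activity at Neuronal acetylcholine receptor; alpha3/beta4 (Homo sapiens), read by fluorescence and calcium flux (on this read-out higher numbers stand for weaker inhibition and lower numbers for stronger inhibition), gives 8130 nM;
compound 2, `COc1ccc(CC2CC(=O)N(c3ccccc3C(=O)OCC3CCCN(CCCc4ccccc4)C3)C2=O)cc1`, which in this assay gives 28800 nM;
compound 3, `O=C(OCC1CCCN(CCCc2ccccc2)C1)c1ccccc1N1C(=O)CC(CCc2ccccc2)C1=O`, which in this assay gives 33100 nM.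

Compound 3 sits alongside compound 2: the step of a 1.1-fold higher number from compound 2 to compound 3 (0.06 log units; within the scatter) stays within the scatter, while compound 1 gives a clearly lower number than compound 3. Compound 4, `O=C(OCC1CCCN(CCCc2ccccc2)C1)c1ccccc1N1C(=O)CC(Cc2ccc(Cl)cc2)C1=O`, differs from compound 3 by 4-chlorophenyl in place of benzyl on a saturated chain carbon bound to a saturated ring carbon. Among the compounds with values here, the only measured step at that carbon is a 1.1-fold higher number from compound 2 to compound 3 (0.06 log units; within the scatter), which exchanged one aromatic group for another at the same place and moved the number hardly at all. With another exchange of one aromatic group for another at that place, the step of a 1.1-fold lower number from compound 3 to compound 4 (0.04 log units; within the scatter) is expected to remain within the scatter. Compound 4 is therefore estimated to give 30000 nM in this assay, with a range of 12000 nM to 75000 nM.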

Compound 4, half-maximal inhibitory concentration: 14500 nM
Estimate against measurement, compound 4: 2.1-fold (0.32 log units) above; low and high end bracket the measured number.
By their numbers in this assay, from the lowest: compounds 1, 4, 2 and 3 (each within the scatter of the next, the first and the last beyond it).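

In this assay, within the data shown here, this carbon proved not indifferent to the exchange of one aromatic group for another: the step of a 2.3-fold lower number from compound 3 to compound 4 (0.36 log units; beyond the scatter) is the first there to pass beyond the scatter, with 4-chlorophenyl in place of benzyl. The step of a 2.0-fold lower number from compound 2 to compound 4 (0.30 log units; within the scatter) shows that chloro and methoxy on that aromatic carbon cannot be told apart here. Nothing available explains the shift. Open remains whether a bromo or an amino group on that aromatic carbon would give a number like that of compound 4, and whether a longer chain at the saturated carbon would hold it.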